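The compounds below may be only part of what the source reports. "The series", "measured", "known", "first", "only" and "open" are said of these compounds alone.

Going by the values given here, compound 2, with the structure `O=c1nc(N2CCN(Cc3ccc(OC(F)(F)F)cc3)CC2)sc2c([N+](=O)[O-])cc(C(F)(F)F)cc12`, is one of two compounds measured so far in an ADME assay on microsomes from liver (Homo sapiens) for metabolic stability, with a stated time of 90 min, tested at 20 uM (a higher number here means faster removal of the compound, a lower number slower removal), where compound 2 gives 32.1 mL.min-1.g-1. The other measured compound is compound 1, with the structure `O=c1nc(N2CC[C@H](c3ccccc3)[C@@H](O)C2)sc2c([N+](=O)[O-])cc(C(F)(F)F)cc12`, which in this assay gives 26.7 mL.min-1.g-1; the two readings lie within the usual scatter of each other, so neither can be called faster or slower to clear.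

Compound 3, with the structure `CN(C(=O)CN1CCN(c2nc(=O)c3cc(C(F)(F)F)cc([N+](=O)[O-])c3s2)CC1)c1ccccc1`, has not yet been measured. It differs from compound 2 in one place: methyl(phenyl)carbamoyl in place of 4-(trifluoromethoxy)phenyl on a saturated chain carbon bound to an amine nitrogen in a ring. Among the compounds with values here, since no step between two measured compounds tracks this kind of change, there is nothing in the data to indicate a direction for it, and the two measured compounds give values close to each other.

The expected step from compound 2 to compound 3 is therefore a 1.1-fold lower number from compound 2 to compound 3 (0.03 log units; within the scatter), that is, none beyond the scatter. Compound 3 is estimated to give 30 mL.min-1.g-1, with a range from 14 mL.min-1.g-1 to 62 mL.min-1.g-1.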

Compound 3, intrinsic clearance in microsomes: 15.8 mL.min-1.g-1
The estimate for compound 3 lay 1.9-fold (0.28 log units) above the measured number; measured number inside the range.
By their numbers in this assay, from the lowest: compounds 3, 1 and 2 (each within the scatter of the next, the first and the last beyond it).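

At this position, on a saturated chain carbon bound to an amine nitrogen in a ring, the change does register in this assay: methyl(phenyl)carbamoyl in place of 4-(trifluoromethoxy)phenyl gives a 2.0-fold lower number from compound 2 to compound 3 (0.31 log units; beyond the scatter), a modest step that only just clears the scatter. Going by these compounds alone, the earlier compounds offered no step in one place, so this is the first sign that the group carried here can shift how fast the compound is removed. Both groups hold a six-membered aromatic ring of carbon only and no hydrogen-bond donor, so the step belongs to the exchange as a whole, and no measurement shown here accounts for it.

Which part of the exchange matters stays open: the loss of the trifluoromethoxy group, the gain of the carbonyl, or the methyl on the amide nitrogen. A plain benzyl group or a phenylcarbamoyl group without that methyl would help separate these parts, and the compounds shown also leave open how a carboxylic acid on this chain would read.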